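A few compounds are considered here, and "the series" means these few. Any claim that something is new, unique, unknown or untested is made for them only; others in the source may bear on it.

Compound 1 `N/C(=N\NC(=S)N1CCOCC1)c1ccccn1`: 40% in a functional assay on HeLa cells (Homo sapiens) for cytotoxicity, read by MTT assay, with a stated time of 72 h, tested at 3 uM; on this read-out lower numbers stand for less inhibition of growth and higher numbers for more inhibition of growth at the one concentration tested
Compound 2 `Cc1ccnc(/C(N)=N/NC(=S)N2CCOCC2)c1`: 44.7% in this assay
Compound 3 `Cc1cccc(/C(N)=N/NC(=S)N2CCSCC2)n1`: 54.6% in this assay

Among these three numbers compound 1 stands lowest. Its nearest neighbour is compound 2, and the step of a number 4.7 percentage points higher from compound 1 to compound 2 (within the scatter) lies within the scatter, so the two cannot be told apart. Compound 3 lies further off; its number is higher than that of compound 1, but compound 3 differs from compound 1 in two places at once, so its value says nothing on its own about either change.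

Compound 4 `N/C(=N\NC(=S)N1CCCCC1)c1ccccn1` is not yet measured. It differs from compound 1 in one place: piperidin-1-yl in place of morpholin-4-yl on a thiocarbonyl carbon. Going by the values given here, none of the measured steps touches this ring; the only single-change step, the one from compound 1 to compound 2, concerns a methyl group elsewhere. Among the compounds with values here, with no direct precedent, the expectation for compound 4 rests on the narrow spread of the three known numbers. A step of a number 6 percentage points higher from compound 1 to compound 4 (within the scatter) is expected, which would sit within the scatter. Compound 4 is therefore estimated at 46% in this assay, with a range from 30% to 64%.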

Compound 4, percent growth inhibition at one concentration: 49.2%
Compound 4: the middle estimate sits 3.2 percentage points below what was measured, within the range that was stated.
By their numbers in this assay, from the lowest: compounds 1, 2, 4 and 3 (each within the scatter of the next, the first and the last beyond it).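

Exchanging the ring on the thiocarbonyl carbon, with piperidin-1-yl in place of morpholin-4-yl, gives in this assay a number 9.2 percentage points higher from compound 1 to compound 4 (within the scatter). This is the first single change shown at this position, and it indicates that the ring oxygen of morpholin-4-yl can be replaced by a carbon without a shift that can be told apart from ordinary repeat variation, at least on the shared core of compound 1 and at the one concentration tested. No separate measurement bears on this result, so nothing can be said about what lies behind it.

Still open, going by these compounds, is whether a ring of another kind on the same thiocarbonyl carbon, such as piperazin-1-yl with its second ring nitrogen, or an open-chain group such as diethylamino, would stay close to compound 1 and compound 4 or move clearly away from them. Also open, on these data alone, is whether the closeness of compound 1 and compound 4 would hold on a core carrying a methyl group, or at other concentrations, since a single reading at one concentration gives no full picture of how growth inhibition changes with dose.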